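This account rests on a few compounds, and the source may have more. Where it says the series, first, only, none or still open, it means among the compounds named here.

Series notes on the step from compound 1 to compound 3. Compound 1 `COc1ccc(-c2c(C)nc3c(NCCNC(C)=O)cc(Cl)nn23)cc1OC` has been run in an ADME assay on HeLa cells (Homo sapiens) for cytotoxicity (a lower number here means that less compound is tolerated, a higher number that more compound is tolerated), and compound 1 reaches only the limit of the assay, > 50000 nM. Compound 2 `CC(=O)NCCNc1cc(Cl)nn2c(-c3ccc(F)c(C=O)c3)c(C)nc12` also returns only a limit in this assay, > 50000 nM. Both shown values therefore sit at the limit of > 50000 nM in this assay, at which 2 of the 2 values shown sit, so no number for compound 1 is known beyond that limit. Compound 3 `COc1ccc(-c2c(C)nc3c(N)cc(Cl)nn23)cc1OC` is not yet measured and differs from compound 1 by hydrogen in place of 2-acetamidoethyl on a nitrogen on an aromatic ring. No step beyond the scatter is expected in this assay in either direction. Compound 3 is expected to give 60000 nM, most likely again only a limit, within 30000 nM to 200000 nM, an expected step that the limit leaves unreadable from compound 1 to compound 3.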

Compound 3, half-maximal cytotoxic concentration: > 1750 nM
Compound 3 gave a limit, no number; the forecaster's own chance of this, stated with the estimate: 80%; the middle value does not contradict the limit.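

Among these compounds, compound 1 and compound 3 both return only limits in this assay, so no step between them can be read. The compounds shown leave open whether hydrogen in place of 2-acetamidoethyl on a nitrogen on an aromatic ring changes the half-maximal cytotoxic concentration at all.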